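The compounds below may be only part of what the source reports. "The series", "measured", "known", "first", "only" and "open" are said of these compounds alone.

Of the compounds shown here, three have so far been measured in a functional assay on HT-29 cells (Homo sapiens) for antiproliferative activity, read by MTT assay, with a stated time of 72 h; on this read-out higher numbers stand for weaker inhibition and lower numbers for stronger inhibition. Compound 1 `O=C(Nc1ccc(Oc2ccnc3[nH]ccc23)cc1)c1cc2cccnc2n(-c2ccc(Cl)cc2)c1=O` gives 280 nM in this assay. Compound 2 `Cn1ccc2c(Oc3ccc(NC(=O)c4cc5cccnc5n(-c5ccccc5)c4=O)cc3)ccnc21` gives 620 nM in this assay. Compound 3 `Cn1ccc2c(Oc3ccc(NC(=O)c4cc5cccnc5n(-c5ccc(F)cc5)c4=O)cc3)ccnc21` gives 250 nM in this assay, which is the lowest of the three numbers; compound 1 is the nearest to it, and the gap between the two lies within the usual scatter, while compound 2 is the furthest, with a gap beyond the scatter. Among the compounds with values here, the only single-point step among the measured compounds is a 2.5-fold lower number from compound 2 to compound 3 (0.39 log units; beyond the scatter), a modest change.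

Compound 4 `Cn1ccc2c(Oc3ccc(NC(=O)c4cc5cccnc5n(-c5ccc(Cl)cc5)c4=O)cc3)ccnc21` differs from compound 3 in one place: chloro in place of fluoro on an aromatic carbon. Within the data shown here, no measured step swaps fluoro for chloro on an aromatic carbon, so the step from compound 2 to compound 3 bears on it only loosely, as a sign that a small halogen there matters modestly. Compound 1 also carries chloro rather than fluoro on an aromatic carbon, though it differs from compound 4 elsewhere, and its value and that of compound 3 sit within the scatter of each other. The expected step for compound 4 is therefore a 1.1-fold lower number from compound 3 to compound 4 (0.04 log units; within the scatter), that is, none beyond the scatter. Compound 4 is estimated at 230 nM in this assay, with a range from 100 nM to 550 nM.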

Compound 4, half-maximal inhibitory concentration: 730 nM
The estimate for compound 4 lay 3.2-fold (0.50 log units) below the measured number; measured number outside the range, above it.
By their numbers in this assay, from the lowest: compounds 3 and 1 (each within the scatter of the next); then compounds 2 and 4 (each within the scatter of the next).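

In this assay, the two halogens are not interchangeable at this position: going from 4-fluorophenyl to 4-chlorophenyl gives a 2.9-fold higher number from compound 3 to compound 4 (0.47 log units; beyond the scatter), while chloro in place of hydrogen gives only a 1.2-fold higher number from compound 2 to compound 4 (0.07 log units; within the scatter), so the chloro and unsubstituted compounds cannot be told apart here, although fluoro in place of hydrogen did give a 2.5-fold lower number from compound 2 to compound 3 (0.39 log units; beyond the scatter). Within the data shown here, the result also gives the first single-change reading at the aromatic nitrogen of the core, where methyl in place of hydrogen, with chloro on the phenyl ring in both compounds, gives a 2.6-fold higher number from compound 1 to compound 4 (0.42 log units; beyond the scatter), so the similar numbers of compound 1 and compound 3 did not mean that this nitrogen or this halogen made no difference. Nothing available explains why fluoro and chloro behave differently here, or why the methyl changes the number.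

From the compounds shown here alone, whether the step at the nitrogen would be the same with fluoro on the phenyl ring remains open, since only the chloro pair can be read. Going by these compounds, it also remains open how other groups at this position, such as methoxy, nitrile or trifluoromethyl, would compare with fluoro and chloro.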